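From Compound 3 to Compound 4: a Ring Swap on the Carbonyl

The source may report more compounds than this note shows. Statements on the series, on what has been measured and on what is new or still open speak of the compounds shown alone.

Measured in an assay on HEK293 cells for positive allosteric modulation of metabotropic glutamate receptor 5 (Homo sapiens), read by FLIPR; on this read-out higher numbers stand for an effect only at larger amounts of compound and lower numbers for an effect already at smaller amounts:
Compound 1 `O=C([C@H]1CC2CCC1C2)N1CC(c2nc(-c3ccccc3)no2)C1`: 120 nM
Compound 2 `O=C(c1ccccc1F)N1CC[C@H]1c1nc(-c2cccc(F)c2)no1`: only a limit, > 10000 nM
Compound 3 `CC1CCC(C(=O)N2CC(c3nc(-c4cccc(Cl)c4)no3)C2)CC1`: 1500 nM

Of the two compounds with a number, compound 3 stands highest; compound 1 lies below it by a gap beyond the usual scatter. Compound 2 gives no number at all in this assay, only a limit.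

Compound 4 `CC1CCN(C(=O)N2CC(c3nc(-c4cccc(Cl)c4)no3)C2)C1` differs from compound 3 in one place: 3-methylpyrrolidin-1-yl in place of 4-methylcyclohexyl on a carbonyl carbon. Within the data shown here, no measured pair shows this change, so the size of the step is unknown. A change of this kind, which keeps the ring but replaces a carbon with the attaching nitrogen, is expected to move the number only modestly, and the direction is uncertain, with a small loss slightly more probable. Compound 4 is therefore estimated at 2200 nM, within 600 nM to 8000 nM, meaning an expected step of a 1.5-fold higher number from compound 3 to compound 4 (0.17 log units; within the scatter).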

Compound 4, half-maximal effective concentration: > 10000 nM
Compound 4: a limit, no number; the forecaster's own chance of this, stated with the estimate: 15%; middle value at least 4.5-fold (0.65 log units) away from the limit.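

In this assay, among these compounds, the place on the carbonyl carbon proves less forgiving than the earlier compounds could show: 3-methylpyrrolidin-1-yl in place of 4-methylcyclohexyl gives an at least 6.6-fold higher number from compound 3 to compound 4 (0.82 log units; beyond the scatter). The value of compound 4 is a limit and not a number, so the full size of this step stays unknown: the limit of > 10000 nM in this assay, at which 2 of the 4 values shown sit.

The compounds shown leave open whether the loss goes with the attaching nitrogen or with the five-membered ring, as both change together in this step. A piperidine ring attached through its nitrogen, or a cyclopentyl group, on the same carbonyl carbon would tell these apart.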